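A few compounds are considered here, and "the series" means these few. Any claim that something is new, unique, unknown or untested is made for them only; others in the source may bear on it.

In an ADME assay on CCRF-CEM cells (Homo sapiens) for metabolic stability, read by HPLC, at 37 degrees C (on this read-out higher numbers stand for a longer-lived compound and lower numbers for a shorter-lived compound), compound 1 `Cc1cn([C@H]2C=C[C@@H](COP(=O)(O)OP(=O)(O)OCc3ccc(OC(=O)c4ccc(C(F)(F)F)cc4)cc3)O2)c(=O)[nH]c1=O` gives 11.5 h and compound 2 `Cc1ccc(C(=O)Oc2ccc(COP(=O)(O)OP(=O)(O)OC[C@@H]3C=C[C@H](n4cc(C)c(=O)[nH]c4=O)O3)cc2)cc1` gives 14.5 h. Compound 3 `CCCCCCCCCCCC(=O)Oc1ccc(COP(=O)(O)OP(=O)(O)OC[C@@H]2C=C[C@H](n3cc(C)c(=O)[nH]c3=O)O2)cc1` gives 1.15 h, the lowest of the three numbers. Compound 4 `CCCCCCCC(=O)Oc1ccc(COP(=O)(O)OP(=O)(O)OC[C@@H]2C=C[C@H](n3cc(C)c(=O)[nH]c3=O)O2)cc1` has not yet been measured. It carries a shorter saturated chain than compound 3: hydrogen in place of butyl on a saturated chain carbon, seven bonds along the chain from a carbonyl carbon, which means hydrogen in place of butyl on a saturated chain carbon, seven bonds along the chain from a carbonyl carbon.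

The closest evidence comes from replacing an aromatic group with undecyl, which gives a 10-fold lower number from compound 1 to compound 3 (1.00 log units; beyond the scatter) and a 13-fold lower number from compound 2 to compound 3 (1.10 log units; beyond the scatter), both beyond the scatter. By contrast, a 1.3-fold higher number from compound 1 to compound 2 (0.10 log units; within the scatter) stays within it. Among the measured compounds shown here, no measured pair changes chain length alone, so these steps offer only a loose guide. Compound 4 keeps a saturated chain, as compound 3 does, so a small upward move in this assay is expected, much smaller than those two large steps. The expected size is a 1.6-fold higher number from compound 3 to compound 4 (0.19 log units; within the scatter). Compound 4 is estimated at 1.8 h, with an expected range of 0.8 h to 5 h.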

Compound 4, half-life: 1.65 h
The estimate for compound 4 lay 1.1-fold (0.04 log units) above the measured number; the measured number falls inside the stated range.
By their numbers in this assay, from the lowest: compounds 3 and 4 (each within the scatter of the next); then compounds 1 and 2 (each within the scatter of the next).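

Among the compounds shown here, removing butyl from the chain, seven bonds along from the carbonyl carbon, gives a 1.4-fold higher number from compound 3 to compound 4 (0.16 log units; within the scatter) in this assay, the first measured pair in which chain length alone changes, and the two values cannot be told apart. Heptyl on the carbonyl carbon, like undecyl, stays well apart from the aromatic groups: heptyl in place of 4-methylphenyl gives an 8.8-fold lower number from compound 2 to compound 4 (0.94 log units; beyond the scatter), and heptyl in place of 4-(trifluoromethyl)phenyl gives a 7.0-fold lower number from compound 1 to compound 4 (0.84 log units; beyond the scatter), so the gap seen with undecyl also holds for this shorter saturated chain. No measurement here offers a reason for these numbers.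

On these data alone, whether a much shorter chain such as propyl would stay with compound 3 and compound 4 or move towards compound 1 and compound 2 remains open. So does the effect of a longer chain, or of a chain ending in an amine or a carboxylic acid.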